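Phenylsulfonyl for oxazolylcarbonyl: expected cytotoxicity of compound 4

The compounds below may be only part of what the source reports. "The series", "measured", "known", "first", "only" and "open" are said of these compounds alone.

Three measured compounds share one core and differ only in the group on the nitrogen on the aromatic ring. In an ADME assay on HepG2 2.2.15 cells (Homo sapiens) for cytotoxicity (on this read-out higher numbers stand for lower toxicity in this test and lower numbers for higher toxicity in this test), compound 1 `O=C(Nc1ncc(C(Oc2ccc3cc(Br)ccc3c2)c2ccc(Cl)cc2)s1)C1CC1` is reported as "not toxic" (no number reported). Compound 2 `N#Cc1cccc(C(=O)Nc2ncc(C(Oc3ccc4cc(Br)ccc4c3)c3ccc(Cl)cc3)s2)c1` gives > 50000 nM in this assay, which is a limit of the assay and not a number. Compound 3 `Cc1noc(C)c1C(=O)Nc1ncc(C(Oc2ccc3cc(Br)ccc3c2)c2ccc(Cl)cc2)s1` is likewise reported in this assay as "not toxic" (no number reported), so no single number places it; the only numeric anchor in the set is the limit of > 50000 nM in this assay, at which 1 of the 3 values shown sits.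

Compound 4 `O=S(=O)(Nc1ncc(C(Oc2ccc3cc(Br)ccc3c2)c2ccc(Cl)cc2)s1)c1ccccc1` carries phenylsulfonyl in place of (3,5-dimethyl-1,2-oxazol-4-yl)carbonyl on a nitrogen on an aromatic ring. For the measured compounds named here, no step between measured compounds is available for this change, and none of the three measured compounds shows toxicity in this assay, so the step from compound 3 to compound 4 is expected to stay within the scatter with no direction. Compound 4 is therefore estimated at 60000 nM in this assay, within a range of 15000 nM to 250000 nM, most likely reported again only as a limit.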

Compound 4, half-maximal cytotoxic concentration: > 50000 nM
Compound 4 ended at the assay's limit (the forecaster's own chance of this, stated with the estimate: 75%); the middle value lies beyond the limit too.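

In this assay, no step can be read from compound 2 to compound 4, as both stand at a limit of the assay and not at a number: the limit of > 50000 nM in this assay, at which 2 of the 4 values shown sit.

The compounds shown leave open whether the groups on this nitrogen differ at all in this assay.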